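A few compounds are considered here, and "the series" means these few. Any claim that something is new, unique, unknown or untested is made for them only; others in the source may bear on it.

In a functional assay on COLO 205 cells (Homo sapiens) for cytotoxicity, read by MTT assay, with a stated time of 48 h (on this read-out lower numbers stand for stronger inhibition and higher numbers for weaker inhibition), compound 1 (`Oc1ccc(Nc2nc(-c3cccc(F)c3)nc3ccc(F)cc23)cc1`) gives > 50000 nM as a limit of the assay and not a number. Compound 2 (`Oc1cccc(Nc2nc(-c3cccc(F)c3)nc3ccc(F)cc23)c1`) likewise gives only a limit, > 50000 nM in the same test. Among the compounds with values here, compound 3 (`Nc1cccc(Nc2nc(-c3cccc(F)c3)nc3ccc(F)cc23)c1`) also stands at a limit, with > 50000 nM as its only reading. All three share one ceiling, the limit of > 50000 nM in this assay, at which 3 of the 3 values shown sit, and none of them has a number.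

Compound 4 (`Cc1ccccc1Nc1nc(-c2cccc(F)c2)nc2ccc(F)cc12`) carries 2-methylphenyl in place of 3-aminophenyl on a nitrogen on an aromatic ring.

Within the data shown here, three measured steps bear on this change: a step that the two limits leave unreadable from compound 1 to compound 2 and a step that the two limits leave unreadable from compound 1 to compound 3 and a step that the two limits leave unreadable from compound 2 to compound 3. Each changes the same aromatic ring or a group on it, yet none has a readable size. They therefore offer no sign of a gain or a loss, and no step beyond the scatter is expected in this assay.

The expected change is a number no higher from compound 3 to compound 4 (the limit leaves the size open) as an estimate resting on limits alone. Compound 4 is expected near 50000 nM with an estimated range from 20000 nM to 100000 nM in this assay.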

Compound 4, half-maximal inhibitory concentration: > 50000 nM
Compound 4 was reported as a limit; the forecaster's own chance of this, stated with the estimate: 70%; the middle value sits exactly at the limit.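

Compound 4 gives > 50000 nM in this assay as a limit and not a number. Its steps from compound 1, compound 2 and compound 3 therefore cannot be read, since all four share one ceiling: the limit of > 50000 nM in this assay, at which 4 of the 4 values shown sit.

The compounds shown leave open whether any of these ring changes alters the value, and what number any of the four would have.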